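From Z to E at the Double Bond of Compound 3

The source may hold more compounds than are shown below. What is called first, only, known or untested is meant among the compounds shown, and "the series" means these compounds.

Measured in a functional assay on BMEC cells (Bos taurus) for antiproliferative activity; a lower number here means a stronger inhibitor, a higher number a weaker inhibitor:
- Compound 1 `COc1cc(/C=C/Cc2cc(O)c3cc(-c4ccccc4)oc3c2)cc(OC)c1OC`: > 20000 nM, a limit of the assay
- Compound 2 `COc1cc(/C=C\Cc2cc(OC)c3ccsc3c2)cc(OC)c1OC`: 8100 nM
- Compound 3 `COc1cc(/C=C\Cc2cc(O)c3sccc3c2)cc(OC)c1OC`: 350 nM

Compound 3 holds the lowest of the two actual numbers, and compound 2 lies higher, beyond the scatter. Compound 4 `COc1cc(/C=C/Cc2cc(O)c3sccc3c2)cc(OC)c1OC` is the next case. the two compounds have the same atoms and bonds and differ only in configuration as drawn: 1 of 1 stereo elements differ; a double bond is drawn Z in compound 3 and E in compound 4 The two compounds have the same atoms and bonds, and a double bond is drawn Z in compound 3 and E in compound 4. Going by the values given here, no measured pair shows this change alone. Compound 1, also drawn E but with a different core, stands at the limit > 20000 nM. On that slim basis, the expected step in this assay is a 14-fold higher number from compound 3 to compound 4 (1.15 log units; beyond the scatter), towards a weaker inhibitor. For compound 4 the estimated value is 5000 nM, with an expected range from 1000 nM to 20000 nM.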

Compound 4, half-maximal inhibitory concentration: 24800 nM
Compound 4: the middle estimate sits 5.0-fold (0.70 log units) below what was measured; the whole stated range lies below it.
By their numbers in this assay, from the lowest: compound 3; then compound 2; then compound 4.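

In this assay, the configuration of the double bond alone accounts for a 71-fold higher number from compound 3 to compound 4 (1.85 log units; beyond the scatter), and no earlier pair had isolated this change. The step can be assigned to the double bond itself, because nothing else separates the two compounds: the fact that compounds 3 and 4 differ only in the configuration as drawn. Within this pair, the Z drawing goes with the stronger inhibitor.

The compounds shown leave open whether the Z form keeps so large an advantage on the core of compound 1. As far as these compounds go, it is also open whether the step persists when an amine or a carboxylic acid is carried on the shared core.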